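This account rests on a few compounds, and the source may have more. Where it says the series, first, only, none or still open, it means among the compounds named here.

Working notes on the series. Of the compounds shown here, three on the shared core have been measured in an ADME assay on microsomes from liver (Homo sapiens) for metabolic stability; on this read-out higher numbers stand for a longer-lived compound and lower numbers for a shorter-lived compound. Compound 1 `CC(C)[C@@H](C[C@H]1SC(=O)NC1=O)c1ccc(-c2ccc3cccc(F)c3c2)[nH]c1=O` gives 1.24 h. Compound 3 `CCC(/C=C1\OC(=O)NC1=O)(CC)c1ccc(-c2ccc3cccc(F)c3c2)[nH]c1=O` gives 0.948 h. Compound 2 `CC(C)C(c1ccc(-c2ccc3cccc(F)c3c2)[nH]c1=O)C1C(=O)NC(=O)N1C` gives 0.375 h, the lowest of the three numbers; the nearest is compound 3 and the furthest compound 1, and both gaps lie beyond the usual scatter. For the measured compounds named here, no pair among the three differs in a single place, so no step between measured compounds can be read off.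

Compound 4 `CC(C)C(/C=C1\NC(=O)NC1=O)c1ccc(-c2ccc3cccc(F)c3c2)[nH]c1=O` is not yet measured. Its difference from compound 2 is a group of 8 heavy atoms (4 carbon, 2 nitrogen, 2 oxygen; one five-membered non-aromatic ring with 2 hetero atoms) in place of a group of 8 heavy atoms (4 carbon, 2 nitrogen, 2 oxygen; one five-membered non-aromatic ring with 2 hetero atoms), on a saturated chain carbon bound to an aromatic carbon and a saturated chain carbon. The group that leaves is the 3-methyl-2,5-dioxoimidazolidin-4-yl; the group that enters has no common name and shows 3 double bonds outside aromatic rings and 2 hydrogen-bond donors where the leaving group shows 2 double bonds outside aromatic rings and 1 hydrogen-bond donor, at the same place on a saturated chain carbon bound to an aromatic carbon and a saturated chain carbon.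

Because compound 2 stands lowest, with compound 1 at 1.24 h and compound 3 at 0.948 h both beyond the scatter above it, the step of a 2.3-fold higher number from compound 2 to compound 4 (0.36 log units; beyond the scatter) is expected to be upward and beyond the scatter. The estimate for compound 4 in this assay is 0.85 h, with a range from 0.4 h to 1.7 h.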

Compound 4, half-life: > 3 h
Compound 4: only a limit was reported; the forecaster's own chance of this, stated with the estimate: 5%; middle value at least 3.5-fold (0.54 log units) from the limit.
By their numbers in this assay, from the lowest: compound 2; then compounds 3 and 1 (each within the scatter of the next). At a limit, above all of these: compound 4.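

In this assay, the exchange of the 3-methyl-2,5-dioxoimidazolidin-4-yl for the entering ring, on a saturated chain carbon bound to an aromatic carbon and a saturated chain carbon, is an at least 8.0-fold higher number from compound 2 to compound 4 (0.90 log units; beyond the scatter). Going by these compounds, compound 4 reads > 3 h, which is a limit and not a number, so the true size of the step stays unknown and only its lower bound can be read: the limit of > 3 h in this assay, at which 1 of the 4 values shown sits. For the compounds shown here, this is the first single-place comparison, and it shows that this position responds strongly in this read-out to a change that leaves the heavy-atom count and the composition of the group the same, while the group goes from 2 to 3 double bonds outside aromatic rings and from 1 to 2 hydrogen-bond donors.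

Going by these compounds alone, the one pair cannot separate the added double bond from the added hydrogen-bond donor, and it does not fix how far the half-life of compound 4 lies past the limit. On these data alone, how a carboxylic acid or an amine would read on this same saturated chain carbon remains open, as does whether the entering ring would give a similar step on the side chains of the other compounds.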